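The compounds below may be only part of what the source reports. "The series", "measured", "known", "first", "only" and "open" are said of these compounds alone.

Measured so far in an assay on mitochondria from L6 cells (Rattus norvegicus) for activation, with a stated time of 90 min; a higher number here means that more compound is needed for the effect, a lower number that less compound is needed:
Compound 1 `Oc1nc2nonc2nc1Nc1ccccc1C(F)(F)F` gives 10600 nM.
Compound 2 `Oc1nc2nonc2nc1Nc1ccc(C(F)(F)F)cc1` gives 10400 nM.
Compound 3 `Oc1nc2nonc2nc1Nc1ccccc1Cl` gives 6300 nM.

Compound 1 and compound 2 are built from the same atoms joined differently; the difference between the two cores is not broken down here, and their values in this assay lie within the scatter of each other. Compound 3 differs from compound 1 by chloro in place of trifluoromethyl on an aromatic carbon, and that step was a 1.7-fold lower number from compound 1 to compound 3 (0.23 log units; within the scatter). Compound 4 `Oc1nc2nonc2nc1Nc1ccc(Cl)cc1` has not yet been measured; it differs from compound 2 by chloro in place of trifluoromethyl on an aromatic carbon. Around the place the two differ: in compound 3 the group sits ortho to a large group, in compound 4 para to a large group, so this is the same kind of change, not the same change. A similar step is expected, a 1.6-fold lower number from compound 2 to compound 4 (0.20 log units; within the scatter), because the earlier step of a 1.7-fold lower number from compound 1 to compound 3 (0.23 log units; within the scatter) stayed within the scatter. Compound 4 is therefore expected to give about 6500 nM, likely between 3000 nM and 14000 nM.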

Compound 4, half-maximal effective concentration: 11700 nM
Estimate against measurement, compound 4: 1.8-fold (0.26 log units) below; measured number inside the range.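

In this assay, putting chloro in place of trifluoromethyl on the second core gave a 1.1-fold higher number from compound 2 to compound 4 (0.05 log units; within the scatter), so the step is small here as well. Set beside the earlier step, the two cannot be told apart: the same change on two cores in this assay, a 1.7-fold lower number (0.23 log units; within the scatter) from compound 1 to compound 3 and a 1.1-fold higher number (0.05 log units; within the scatter) from compound 2 to compound 4, 1.9-fold (0.28 log units) apart, within the scatter of two such steps This shows that the change carried from one core to the other without a detectable difference, but since each step lies within the scatter, it does not show that the change itself does anything on either core.

The compounds shown carry only chloro and trifluoromethyl on the outer aromatic ring, so it remains open how an amine, a methoxy group or a carboxylic acid would behave there. Going by these compounds, whether the same holds on any further core also remains open.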